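This account rests on a few compounds, and the source may have more. Where it says the series, first, only, none or still open, it means among the compounds named here.

The three measured compounds share one core and differ only in the aromatic group attached to the urea nitrogen. Compound 1 `O=C(Nc1cccc2nonc12)N1CCN(Cc2cccc(Oc3ccc(Cl)cc3)c2)CC1` gives 28 nM in an assay on isolated protein for inhibition of Fatty-acid amide hydrolase 1 (Homo sapiens), with a stated time of 60 min; a higher number here means a weaker inhibitor, a lower number a stronger inhibitor. Compound 2 `Cc1nc2cc(NC(=O)N3CCN(Cc4cccc(Oc5ccc(Cl)cc5)c4)CC3)ccc2o1` gives 7.7 nM in this assay, and compound 3 `O=C(Nc1noc2ccncc12)N1CCN(Cc2cccc(Oc3ccc(Cl)cc3)c2)CC1` gives 180 nM. Compound 3 thus has the highest number of the three, meaning it is the weakest inhibitor shown: the step of a 6.4-fold higher number from compound 1 to compound 3 (0.81 log units; beyond the scatter) and the step of a 23-fold higher number from compound 2 to compound 3 (1.37 log units; beyond the scatter) both lie beyond the scatter.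

Compound 4 `O=C(Nc1cccc2nccn12)N1CCN(Cc2cccc(Oc3ccc(Cl)cc3)c2)CC1` is not yet measured. It differs from compound 3 by a group of 9 heavy atoms (7 carbon, 2 nitrogen; one five-membered aromatic ring with 2 hetero atoms, one six-membered aromatic ring with 1 hetero atom) in place of a group of 9 heavy atoms (6 carbon, 2 nitrogen, 1 oxygen; one five-membered aromatic ring with 2 hetero atoms, one six-membered aromatic ring with 1 hetero atom), on an amide-type nitrogen; the carbon-bearing five-membered ring loses its oxygen and gains a carbon, while the six-membered ring keeps its single hetero atom.

The measured steps that bear on this change are those that alter the same aromatic group, namely a 6.4-fold higher number from compound 1 to compound 3 (0.81 log units; beyond the scatter) and a 23-fold higher number from compound 2 to compound 3 (1.37 log units; beyond the scatter), and both show that swapping this group can move the number by modest to large amounts. For the measured compounds named here, no measured pair matches the exact change to compound 4, so the direction rests on the observation that compound 3 is the weakest of the set and the other two arrangements of this group all gave lower numbers. A modest step downward is therefore expected, a 3.6-fold lower number from compound 3 to compound 4 (0.56 log units; beyond the scatter), and compound 4 is estimated at 50 nM, within a range from 15 nM to 200 nM.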

Compound 4, half-maximal inhibitory concentration: 2.7 nM
Estimate against measurement, compound 4: 19-fold (1.27 log units) above, outside the stated range (below it).
By their numbers in this assay, from the lowest: compound 4; then compound 2; then compound 1; then compound 3.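

On the amide-type nitrogen, two groups with the same ring counts and the same number of heavy atoms can give very different numbers in this assay: the group with 7 carbon and 2 nitrogen atoms replaces the one with 6 carbon, 2 nitrogen and 1 oxygen atoms in a 67-fold lower number from compound 3 to compound 4 (1.82 log units; beyond the scatter), the largest step in the set, so these counts alone do not set the number. Compound 4 also goes beyond the other two groups, with a 2.9-fold lower number from compound 2 to compound 4 (0.46 log units; beyond the scatter) and a 10-fold lower number from compound 1 to compound 4 (1.02 log units; beyond the scatter), which makes it the strongest inhibitor of the four and shows that a six-membered aromatic ring with 1 hetero atom in this group does not by itself bring the weak result seen with compound 3. For the compounds shown here, no supporting measurement is available to say why this swap moves the number so far.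

The compounds shown leave open how much of the result depends on the exact arrangement of atoms within the entering group. They also leave open how a plain phenyl ring on this nitrogen would compare, or whether a methyl or a chlorine added to the entering group would keep the low number.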